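The source may hold more compounds than are shown below. What is called first, only, known or untested is meant among the compounds shown, and "the series" means these compounds.

Among the compounds with values here, compound 1 `CCCc1c(COc2ccc(C(=O)C(C)(C)Cc3nnn[nH]3)cc2)ccc(C(C)=O)c1O` gives 10.8 mg/kg in an in vivo functional assay on the whole organism (Rattus norvegicus) with cysteinyl leukotriene receptor (Homo sapiens) as the target (on this read-out higher numbers stand for an effect only at larger amounts of compound and lower numbers for an effect already at smaller amounts), the highest of the two numbers so far; compound 2 `CCc1c(COc2ccc(C(=O)CC(C)(C)Cc3nnn[nH]3)cc2)ccc(C(C)=O)c1O`, in this assay, gives 1.1 mg/kg, a gap beyond the scatter. Compound 3 `CCCc1c(COc2ccc(C(=O)CC(C)(C)CC(=O)O)cc2)ccc(C(C)=O)c1O` is not yet measured. It differs from compound 1 by 2-(carboxymethyl)-2-methylpropyl in place of 1-((1H-tetrazol-5-yl)methyl)-1-methylethyl on a carbonyl carbon. Within the data shown here, no measured pair shows this exchange, so the step is expected to be small, with compound 3 expected to be within or just beyond the scatter of compound 1, estimated as a 1.8-fold lower number from compound 1 to compound 3 (0.26 log units; within the scatter). Compound 3 is thus estimated at 6 mg/kg, with a range from 2 mg/kg to 20 mg/kg.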

Compound 3, dose for half-maximal effect: 2.9 mg/kg
Compound 3: the middle estimate sits 2.1-fold (0.32 log units) above what was measured; low and high end bracket the measured number.
By their numbers in this assay, from the lowest: compound 2; then compound 3; then compound 1.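

In this assay, within the data shown here, the exchange of 1-((1H-tetrazol-5-yl)methyl)-1-methylethyl for 2-(carboxymethyl)-2-methylpropyl on the carbonyl carbon gives a 3.7-fold lower number from compound 1 to compound 3 (0.57 log units; beyond the scatter) and is the first readable step at this position. The ring-free group therefore serves here at least as well as the tetrazole-bearing one, but ring and chain change together, so the step belongs to the exchange as a whole.

On these data alone, how much each part contributes stays open, as does the reading for an amide or a longer chain at this carbon. No measurement at hand explains the step.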